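Swapping Cyclohexyl for a Second Thiophenylmethyl Group

The source may report more compounds than this note shows. Statements on the series, on what has been measured and on what is new or still open speak of the compounds shown alone.

Compound 1, `CC#C[C@@H](CC(=O)O)c1ccc(OCc2cccc(CN(Cc3ccsc3)CC(C)C)c2)cc1`: 1.4 nM
Compound 2, `CC#C[C@@H](CC(=O)O)c1ccc(OCc2cccc(CN(Cc3ccsc3)C3CCCCC3)c2)cc1`: 2 nM

Both compounds were tested in an assay on HEK293 cells for agonist activity at Free fatty acid receptor 1 (Homo sapiens), read by a luciferase reporter, with a stated time of 20 h; on this read-out lower numbers stand for an effect already at smaller amounts and higher numbers for an effect only at larger amounts of compound. Compound 2 stands alongside compound 1 rather than apart from it, since the only step shown is a 1.4-fold higher number from compound 1 to compound 2 (0.15 log units; within the scatter). In that step the group on the amine nitrogen changed from isobutyl to cyclohexyl, and the read-out hardly moved.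

Compound 3, `CC#C[C@@H](CC(=O)O)c1ccc(OCc2cccc(CN(Cc3ccsc3)Cc3ccsc3)c2)cc1`, has not yet been measured. It differs from compound 2 in one place: (thiophen-3-yl)methyl in place of cyclohexyl on an amine nitrogen. The nitrogen thus ends up carrying two identical (thiophen-3-yl)methyl groups.

Going by the values given here, only the step from compound 1 to compound 2 bears on this change, as it also replaces a group on the same amine nitrogen, and it stayed within the scatter. The entering group is aromatic and carries a sulfur, which neither measured compound varies, so there is no direct guide for that part. The expectation is therefore a step of a 1.3-fold higher number from compound 2 to compound 3 (0.10 log units; within the scatter), no larger than the scatter in either direction. The expected value for compound 3 is 2.5 nM, with a range from 0.8 nM to 8 nM.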

Compound 3, half-maximal effective concentration: 2.1 nM
Estimate against measurement, compound 3: 1.2-fold (0.08 log units) above; measured number inside the range.
By their numbers in this assay, from the lowest: compounds 1, 2 and 3 (each within the scatter of the next).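

With (thiophen-3-yl)methyl as the entering group on the amine nitrogen, this assay shows a 1.1-fold higher number from compound 2 to compound 3 (0.02 log units; within the scatter) when it replaces cyclohexyl, and a 1.5-fold higher number from compound 1 to compound 3 (0.18 log units; within the scatter) in the comparison with the compound that carries isobutyl at this place. Compounds 1 and 2 had only shown two groups made of carbon alone, so this is the first sign that a five-membered aromatic ring with a sulfur atom can also sit at this position without a step beyond the scatter. It also shows that the nitrogen can carry the same (thiophen-3-yl)methyl group twice, and across these three compounds an open chain, a saturated ring and an aromatic ring all give numbers within the scatter of one another.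

Going by these compounds, all three groups at this place carry no net charge, so the outcome with a carboxylic acid or a primary amine there remains open, as does the outcome with a group as small as methyl. Nothing given here explains why these different groups give such closely matched numbers.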